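Thromboxane synthase series: ether in place of tertiary alcohol

The compounds below may be only part of what the source reports. "The series", "measured", "known", "first", "only" and "open" are said of these compounds alone.

Compound 1 `CC(C)(O)C(CCC/C=C(\c1ccccc1)c1cccnc1)C(=O)O` is the reference point of the series. In an assay (Equus caballus) for inhibition of Thromboxane-A synthase (Homo sapiens), using microsomes (a lower number here means a stronger inhibitor, a higher number a weaker inhibitor), compound 1 gives 42 nM, the lowest of the two numbers in hand. Compound 2 `O=C(O)CCCCCCCCC/C=C(/c1ccccc1)c1cccnc1` is the only comparator; in this assay compound 2 gives 520 nM, a higher number that lies beyond the usual scatter. Compound 3 `COCC(CCC/C=C(\c1ccccc1)c1cccnc1)C(=O)O` differs from compound 1 by methoxymethyl in place of 1-hydroxy-1-methylethyl on a saturated chain carbon bound to a carbonyl carbon and a saturated chain carbon. Within the data shown here, no measured step of this kind is available, so the expectation rests on the position of compound 1 alone. A modest loss is expected. Compound 3 is estimated at 100 nM, in the range 30 nM to 350 nM. The expected step from compound 1 to compound 3 is a 2.4-fold higher number from compound 1 to compound 3 (0.38 log units; beyond the scatter).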

Compound 3, half-maximal inhibitory concentration: 41 nM
Compound 3: the middle estimate sits 2.4-fold (0.39 log units) above what was measured; measured number inside the range.
By their numbers in this assay, from the lowest: compounds 3 and 1 (each within the scatter of the next); then compound 2.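

In this assay, methoxymethyl in place of 1-hydroxy-1-methylethyl on this saturated chain carbon gives a 1.0-fold lower number from compound 1 to compound 3 (0.01 log units; within the scatter) and so registers no measurable change. At this position, the hydrogen-bond donor of 1-hydroxy-1-methylethyl can be given up with no shift beyond the scatter in this assay. Nothing in hand accounts for this result.

Open, on these data alone, is how this position responds to an amine, a phenyl ring or a longer ether chain. Also open, as far as these compounds go, is whether hydroxymethyl reads the same as methoxymethyl here.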